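Diethylamino in place of dimethylamino: expectation for compound 3

A few compounds are considered here, and "the series" means these few. Any claim that something is new, unique, unknown or untested is made for them only; others in the source may bear on it.

Measured so far in an ADME assay on L02 cells (Homo sapiens) for cytotoxicity, read by MTT assay, with a stated time of 48 h (on this read-out lower numbers stand for stronger inhibition and higher numbers for weaker inhibition), for this series
- compound 1 `CCn1c(C(=O)NCCN(C)C)ccc1C(CC)(CC)c1ccc(OCC(O)C(C)(C)C)c(C)c1` gives 2600 nM
- compound 2 `CCn1c(C(=O)NCCCN(C)C)ccc1C(CC)(CC)c1ccc(OCC(O)C(C)(C)C)c(C)c1` gives 470 nM

For the measured compounds named here, of the two numbers, compound 2 at 470 nM holds the lower, and compound 1 is its only neighbour. Next comes compound 3 `CCN(CC)CCCNC(=O)c1ccc(C(CC)(CC)c2ccc(OCC(O)C(C)(C)C)c(C)c2)n1CC`, not yet measured in this assay and differing from compound 2 as follows. The change is diethylamino in place of dimethylamino on a saturated chain carbon, three bonds along the chain from an amide-type nitrogen and amounts to diethylamino in place of dimethylamino on a saturated chain carbon, three bonds along the chain from an amide-type nitrogen.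

Going by the values given here, the only measured step with any bearing on this is a 5.5-fold lower number from compound 1 to compound 2 (0.74 log units; beyond the scatter) and it is a different change, (dimethylamino)methyl in place of dimethylamino. It shows that the number can move with a change on this chain, but it gives no direct size or direction for the present swap, and one step sets no trend. From the compounds shown here alone, a small move towards a lower number is therefore expected, though either direction remains open. Expected here is a 1.2-fold lower number from compound 2 to compound 3 (0.07 log units; within the scatter) and nothing beyond the scatter. For compound 3 the estimate is 400 nM and the expected range runs from 150 nM to 1100 nM on this read-out.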

Compound 3, half-maximal inhibitory concentration: 2500 nM
Compound 3: the middle estimate sits 6.3-fold (0.80 log units) below what was measured; the whole stated range lies below it.
By their numbers in this assay, from the lowest: compound 2; then compounds 3 and 1 (each within the scatter of the next).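

Read in this assay, the amine end of the 3-(dimethylamino)propyl chain proves to be a sensitive place: diethylamino in place of dimethylamino gives (a 5.3-fold higher number from compound 2 to compound 3 (0.73 log units; beyond the scatter)), a move opposite in direction to the earlier chain step (a 5.5-fold lower number from compound 1 to compound 2 (0.74 log units; beyond the scatter)). The low number of compound 2 is therefore lost with a change at either of the two places tried, the chain or the amine, and the two routes end at values that cannot be told apart (a 1.0-fold lower number from compound 1 to compound 3 (0.02 log units; within the scatter)). Nothing available bears on why the number moves in this way.

Still open, from the compounds shown here alone, is whether the loss follows the two added carbons of the diethylamino group or is specific to it, which a pyrrolidine or a morpholine at the end of the same propyl chain would help to separate. Also open, going by these compounds, is how chain and amine combine, which a 2-(diethylamino)ethyl or a 4-(dimethylamino)butyl group on the shared core would test.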